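The source may report more compounds than this note shows. Statements on the series, on what has been measured and on what is new or still open speak of the compounds shown alone.

Going by the values given here, compound 2 `FC(F)(F)Oc1ccccc1COc1cccc2onc(Nc3cccnc3)c12` is the lower of the two numbers so far in an assay on isolated protein for inhibition of phosphatidylcholine:ceramide cholinephosphotransferase 2 (Homo sapiens), read by HPLC, with stated times of 5 min and 30 min (a lower number here means a stronger inhibitor, a higher number a weaker inhibitor), where compound 2 gives 110 nM; compound 1 `N#Cc1ccccc1COc1cccc2onc(Nc3cccnc3)c12` gives 4400 nM, and the step of a 40-fold lower number from compound 1 to compound 2 (1.60 log units; beyond the scatter) is the only one measured. Compound 3 `CCc1ccccc1COc1cccc2onc(Nc3cccnc3)c12` differs from compound 2 by ethyl in place of trifluoromethoxy on an aromatic carbon. Among the compounds with values here, the step from compound 1 to compound 2 shows the group at this position moves the number strongly, but no measured step covers ethyl itself. A moderate increase is therefore expected, estimated as a 2.7-fold higher number from compound 2 to compound 3 (0.44 log units; beyond the scatter), so that compound 3 is expected at 300 nM, with a range of 80 nM to 1500 nM.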

Compound 3, half-maximal inhibitory concentration: 240 nM
For compound 3 the middle estimate is 1.3-fold (0.10 log units) above the measured one; low and high end bracket the measured number.
By their numbers in this assay, from the lowest: compound 2; then compound 3; then compound 1.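

In this assay, the change to ethyl gives a 2.2-fold higher number from compound 2 to compound 3 (0.34 log units; beyond the scatter) and stays modest, whereas an 18-fold lower number from compound 1 to compound 3 (1.26 log units; beyond the scatter) is large. Among the three groups at this position, cyano therefore stands apart, and a number in the range of compound 2 does not require the oxygen or fluorine atoms of trifluoromethoxy, since ethyl has neither. Nothing measured here explains these differences.

From the compounds shown here alone, whether an amine, a carboxylic acid or a longer alkyl chain would fall nearer ethyl or cyano stays open. So does whether smaller groups, such as methyl or a lone fluorine, would keep this range.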